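The source may hold more compounds than are shown below. What is called first, only, known or untested is meant among the compounds shown, and "the series" means these compounds.

Compound 1 `Cc1c(C(=O)Nc2ccc(C(F)(F)F)cc2)cnn1Cc1ccc(F)cc1` and compound 2 `CCCCC(CC)NC(=O)c1cnn(-c2ccc(F)cc2)c1C` were both tested in a functional assay with Homo sapiens as the target; a lower number here means a stronger inhibitor, a higher number a weaker inhibitor. In this assay compound 1 gives 3600 nM, the highest of the two numbers, so it is the weaker of the pair. In this assay compound 2 gives 580 nM, a lower number that lies beyond the usual scatter; the two compounds differ in more than one place, so no single change can be read from that gap.

Compound 3 `Cc1c(C(=O)Nc2ccc(C(F)(F)F)cc2)cnn1-c1ccc([N+](=O)[O-])cc1` has not yet been measured. It differs from compound 1 in one place: 4-nitrophenyl in place of 4-fluorobenzyl on an aromatic nitrogen. Nothing measured here isolates this swap, so any expectation is loose. A modest move toward a lower number seems plausible, with the expected step from compound 1 to compound 3 being a 2.0-fold lower number from compound 1 to compound 3 (0.30 log units; within the scatter). In this assay compound 3 is therefore estimated at 1800 nM, within a range from 450 nM to 7000 nM.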

Compound 3, half-maximal inhibitory concentration: 5700 nM
Beside the measured number, compound 3's estimate is 3.2-fold (0.50 log units) below it, and the stated range covers the measured number.
By their numbers in this assay, from the lowest: compound 2; then compounds 1 and 3 (each within the scatter of the next).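

In this assay, 4-nitrophenyl in place of 4-fluorobenzyl on the aromatic nitrogen gives a 1.6-fold higher number from compound 1 to compound 3 (0.20 log units; within the scatter), so the two compounds read as equal. At this position, then, the number does not separate these two groups, even though the entering group carries 2 hydrogen-bond acceptors and the leaving group 0. No separate measurement bears on this result, so the step stands without an explanation.

As far as these compounds go, whether an amine or a carboxylic acid in place of the nitro group, or a longer chain on the aromatic nitrogen, would move the number beyond the scatter remains open. The lower number of compound 2 also cannot be tied to this position, since that compound differs from the others in more than one place.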